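The source may report more compounds than this note shows. Statements on the series, on what has been measured and on what is new or still open speak of the compounds shown alone.

Measured compounds:
Compound 1 `CC(O)c1cn(Cc2cc(=O)oc3cc(O)ccc23)nn1` — in a functional assay on CFPAC-1 cells (Homo sapiens) for inhibition, read by MTT assay, with a stated time of 72 h (on this read-out higher numbers stand for weaker inhibition and lower numbers for stronger inhibition), compound 1 gives > 100000 nM, a limit of the assay rather than a number.
Compound 2 `O=c1cc(Cn2cc(CCCCO)nn2)c2ccc(O)cc2o1` — in this assay compound 2 gives > 100000 nM, again a limit.
Compound 3 `CCCCCCc1cn(Cc2cc(=O)oc3cc(O)ccc23)nn1` — in this assay compound 3 gives > 100000 nM, also a limit.

Compound 1 therefore stands nowhere in particular on these numbers: its value is only a limit, and the two other values shown are limits as well, so that every value sits at the limit of > 100000 nM in this assay, at which 3 of the 3 values shown sit. The steps between the measured compounds, a step that the two limits leave unreadable from compound 1 to compound 2, a step that the two limits leave unreadable from compound 1 to compound 3 and a step that the two limits leave unreadable from compound 2 to compound 3, are all left unreadable by these limits, and none of them can be sized.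

Compound 4 `O=c1cc(Cn2cc(CCc3ccccc3)nn2)c2ccc(O)cc2o1` differs from compound 1 in one place: phenethyl in place of 1-hydroxyethyl on an aromatic carbon. The measured steps that bear on this change are those from compound 1, which exchanged the 1-hydroxyethyl for a 4-hydroxybutyl or a hexyl group; neither gave a readable size. With no readable step among the three measured compounds, compound 4 is expected to remain near the same limit, an estimated step that the limit leaves unreadable from compound 1 to compound 4. The estimate for compound 4 in this assay is 150000 nM, within 40000 nM to 600000 nM, most likely reported as a limit again.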

Compound 4, half-maximal inhibitory concentration: > 100000 nM
Compound 4: no number, only a limit (the forecaster's own chance of this, stated with the estimate: 85%); the middle value lies beyond the limit too.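

In this assay compound 4 gives > 100000 nM as a limit and not a number. Among these compounds, its steps from compound 1, compound 2 and compound 3 therefore cannot be read, and no new step can be sized. The compounds shown leave open whether any group at this place on the shared core gives a readable value in this assay at all.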